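Benzyl extension on the aryl ether of compound 1

This account rests on a few compounds, and the source may have more. Where it says the series, first, only, none or still open, it means among the compounds named here.

Compound 1 `Cc1ccccc1Oc1ccc(N2C[C@@H](C(F)(F)F)C[C@H]2CC(=O)O)cc1` is the reference point of this set. In an assay on HEK293 cells for binding affinity to Free fatty acid receptor 1 (Homo sapiens), read by scintillation counting and radioligand binding, with a stated time of 1 h (on this read-out higher numbers stand for weaker inhibition and lower numbers for stronger inhibition), compound 1 gives 35 nM, the lowest of the two numbers available. Its nearest neighbour is compound 2 `Cc1ccccc1Oc1ccc(N2CCC[C@H]2CC(=O)O)cc1`, which in this assay gives 4400 nM; the step is a 130-fold higher number from compound 1 to compound 2 (2.10 log units; beyond the scatter), a hydrogen in place of the trifluoromethyl on a saturated ring carbon. Compound 3 `O=C(O)C[C@@H]1C[C@H](C(F)(F)F)CN1c1ccc(Oc2ccccc2OC(F)(F)F)cc1` carries a trifluoromethoxy group on the outer ring, but in this assay compound 3 is "not determined" (no result reported), so it contributes no number.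

Compound 4 `COc1ccc(F)c(Cc2cccc(Oc3ccc(N4C[C@@H](C(F)(F)F)C[C@H]4CC(=O)O)cc3)c2C)c1` keeps the whole of compound 1 and differs as follows (2-fluoro-5-methoxybenzyl in place of hydrogen on an aromatic carbon). Among the compounds with values here, no measured step touches this part of the molecule: the single step in hand, a 130-fold higher number from compound 1 to compound 2 (2.10 log units; beyond the scatter), concerns the saturated ring and says nothing about substitution on the aromatic carbon ortho to the methyl group. The expectation therefore rests on compound 1 alone, and a step in either direction beyond the scatter cannot be ruled out from these data. The working estimate keeps compound 4 close to compound 1, with a broad range to reflect the absence of a comparator: compound 4 is expected to give 25 nM in this assay, within 5 nM to 150 nM. The expected step is a 1.4-fold lower number from compound 1 to compound 4 (0.15 log units; within the scatter).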

Compound 4, inhibition constant: 49 nM
Beside the measured number, compound 4's estimate is 2.0-fold (0.29 log units) below it; the measured number falls inside the stated range.
By their numbers in this assay, from the lowest: compounds 1 and 4 (each within the scatter of the next); then compound 2.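

In this assay, the step of a 1.4-fold higher number from compound 1 to compound 4 (0.15 log units; within the scatter) shows that this aromatic carbon, ortho to a methyl group, can carry 2-fluoro-5-methoxybenzyl, with its 10 heavy atoms and additional six-membered aromatic ring, without a change beyond the scatter. Within the data shown here, the earlier compounds gave no readable step on this aromatic ring; the only one concerned the saturated ring (a 130-fold higher number from compound 1 to compound 2 (2.10 log units; beyond the scatter)) and lay beyond the scatter, whereas this much larger addition does not. The data offer no measurement that explains this result.

A plain benzyl, or a benzyl bearing only the fluorine or only the methoxy, would show whether either substituent contributes to the reading at this position. Also open, on these data alone, are whether a benzyl carrying an amine or a carboxylic acid gives a similar number, and how 2-fluoro-5-methoxybenzyl reads on the core of compound 2, which has hydrogen in place of trifluoromethyl.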